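Swapping a Methoxy for a Nitrile on a Cytotoxicity Read-out

A few compounds are considered here, and "the series" means these few. Any claim that something is new, unique, unknown or untested is made for them only; others in the source may bear on it.

Three compounds in this set share one core and differ only in the aryl group attached to it. Compound 1 `COc1cccc(-c2cc(C)c3ncc(CSCCc4ccccc4)n3c2)c1` carries a 3-methoxyphenyl, compound 2 `COc1ccc(-c2cc(C)c3ncc(CSCCc4ccccc4)n3c2)cc1` a 4-methoxyphenyl, and compound 3 `COc1ccc(-c2cc(C)cn3c(CSCCc4ccccc4)cnc23)cc1` places a 4-methoxyphenyl on the core joined the other way round. In an ADME assay on HEL cells (Homo sapiens) for cytotoxicity, with a stated time of 3 days (on this read-out higher numbers stand for lower toxicity in this test and lower numbers for higher toxicity in this test), compound 1 gives 20 ug/mL, compound 2 gives 20 ug/mL and compound 3 gives 20 ug/mL. Among the measured compounds shown here, compound 2 therefore stands level with both of its neighbours on these numbers: the one measured step, no change at the digits printed from compound 1 to compound 2 (within the scatter), stays within the scatter, and the values of compound 2 and compound 3 show no difference either.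

Compound 4 `Cc1cc(-c2cccc(C#N)c2)cn2c(CSCCc3ccccc3)cnc12` is not yet measured. It differs from compound 2 by 3-cyanophenyl in place of 4-methoxyphenyl on an aromatic carbon. For the measured compounds named here, no measured step exchanges a methoxy group for a nitrile, so the only guide is the unchanged read-out across compounds 1, 2 and 3 when the aryl group was varied. On that basis the expected step is no change at the digits printed from compound 2 to compound 4 (within the scatter), with no change beyond the scatter. Compound 4 is therefore estimated to give 20 ug/mL in this assay, within a range from 10 ug/mL to 40 ug/mL.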

Compound 4, minimum cytotoxic concentration: > 100 ug/mL
Compound 4 was reported as a limit; the forecaster's own chance of this, stated with the estimate: 10%; at least 5.0-fold (0.69 log units) between middle value and limit.
By their numbers in this assay, from the lowest: compounds 1, 2 and 3 (each within the scatter of the next). At a limit, above all of these: compound 4.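

In this assay, the aryl group at this position does affect the read-out after all: moving the methoxy group on the ring had left the numbers level, yet an at least 5.0-fold higher number from compound 2 to compound 4 (0.69 log units; beyond the scatter). The cleanest comparison keeps the substituent's place in the group's name, 3-methoxyphenyl against 3-cyanophenyl, and there an at least 5.0-fold higher number from compound 1 to compound 4 (0.69 log units; beyond the scatter), so exchanging methoxy for nitrile is enough on its own to separate the two compounds, with the higher number standing for lower toxicity in this test. The value of compound 4 is a limit of the assay and not a number, so both steps give only a lower bound on the size of the change: the limit of > 100 ug/mL in this assay, at which 1 of the 4 values shown sits.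

The compounds shown do not tell why this exchange matters, or whether the nitrile is needed at all, since other groups in the same place, such as an amine or a carboxylic acid, are absent from the set. They also leave open whether 4-cyanophenyl would behave like 3-cyanophenyl, and whether a nitrile would have the same effect on the core of compound 3.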